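The source may hold more compounds than are shown below. What is called first, only, known or untested is meant among the compounds shown, and "the series" means these compounds.

Measured so far in a functional assay on A2780 cells (Homo sapiens) for cytotoxicity, read by MTT assay, with a stated time of 72 h (on this read-out lower numbers stand for stronger inhibition and higher numbers for weaker inhibition), are two compounds
Compound 1 `CN(C)c1ccc(C(=O)N(CCCCCC(=O)NO)CC(=O)NC2CCCCC2)cc1` gives 1540 nM
Compound 2 `CN(C)c1ccc(C(=O)N(CCCCCC(=O)NO)CC(=O)NC(C)(C)C)cc1` gives 1030 nM

Compound 2 (1030 nM) stands level with compound 1 (1540 nM) within the scatter, so neither separates from the other. Compound 3 `CCCCNC(=O)CN(CCCCCC(=O)NO)C(=O)c1ccc(N(C)C)cc1` keeps the shared core and alters one group relative to compound 2: butyl in place of tert-butyl on an amide-type nitrogen. For the measured compounds named here, only one measured step bears on this place, tert-butyl in place of cyclohexyl on such a nitrogen, and it is a 1.5-fold lower number from compound 1 to compound 2 (0.17 log units; within the scatter). Going by the values given here, no measured compound carries a butyl group, so this evidence is thin. No step beyond the scatter is therefore expected in this assay, and no direction can be called. The estimated step is a 1.2-fold higher number from compound 2 to compound 3 (0.07 log units; within the scatter). Compound 3 is expected at 1200 nM, with an estimated range from 600 nM to 2400 nM.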

Compound 3, half-maximal inhibitory concentration: 1900 nM
Compound 3: middle estimate off by 1.6-fold (0.20 log units), on the low side, and the stated range covers the measured number.
By their numbers in this assay, from the lowest: compounds 2, 1 and 3 (each within the scatter of the next).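

In this assay, butyl on the amide-type nitrogen gives a 1.8-fold higher number from compound 2 to compound 3 (0.27 log units; within the scatter), and the comparison with the ring-bearing compound gives a 1.2-fold higher number from compound 1 to compound 3 (0.09 log units; within the scatter). The earlier pair compared only cyclohexyl and tert-butyl, whereas the series now includes an open butyl chain, and all three groups remain level within the scatter. Rearranging the same carbon atoms from tert-butyl to butyl therefore does not separate the compounds here, and nothing available explains why these groups read alike.

On these data alone, it remains open whether a phenyl ring, a longer alkyl chain or a chain ending in an amine or a carboxylic acid on this nitrogen would produce a step beyond the scatter. These compounds also leave open whether the same level readings would hold in any other assay.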